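The source may report more compounds than this note shows. Statements on the series, on what has been measured and on what is new or still open speak of the compounds shown alone.

Measured compounds:
compound 1, `CC1C(=O)N(CCCCCCOc2ccc(Cl)cc2)/C(=N\C#N)N1c1ccncc1`: 382 nM
compound 2, `CC1C(=O)N(CCCCCCCOc2ccc(Cl)cc2)/C(=N\C#N)N1c1ccncc1`: 688 nM
compound 3, `N#C/N=C1\N(CCCCCCOc2ccc(Cl)cc2)C(=O)CCN1c1ccncc1`: 3050 nM

All numbers come from a functional assay on HA22T cells for cytotoxicity against HA22T cell line (Homo sapiens); on this read-out higher numbers stand for weaker inhibition and lower numbers for stronger inhibition. Compound 1 and compound 2 share a core and differ by (4-chlorophenoxy)methyl in place of 4-chlorophenoxy on a saturated chain carbon, six bonds along the chain from an amide-type nitrogen in a ring; the resulting step is a 1.8-fold higher number from compound 1 to compound 2 (0.26 log units; within the scatter). Compound 3 carries the chain and end group of compound 1 on another core; how the two cores differ is not broken down here. In this assay compound 3 gives 3050 nM, the highest of the three numbers, beyond the scatter from compound 2 and from compound 1.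

Compound 4, `N#C/N=C1\N(CCCCCCCOc2ccc(Cl)cc2)C(=O)CCN1c1ccncc1`, is not yet measured. It stands to compound 3 as compound 2 stands to compound 1: the change is (4-chlorophenoxy)methyl in place of 4-chlorophenoxy on a saturated chain carbon, six bonds along the chain from an amide-type nitrogen in a ring, the same change made on the core of compound 3. Within the data shown here, the only guide to its size is the one measured instance, which stayed within the scatter. The step for compound 4 is therefore expected to be small, a 1.5-fold higher number from compound 3 to compound 4 (0.17 log units; within the scatter), leaning upward because a 1.8-fold higher number from compound 1 to compound 2 (0.26 log units; within the scatter) pointed that way. Compound 4 is thus estimated at 4500 nM in this assay, with a range from 2400 nM to 9000 nM expected.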

Compound 4, half-maximal inhibitory concentration: 7560 nM
Compound 4: the middle estimate sits 1.7-fold (0.23 log units) below what was measured, and the stated range covers the measured number.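

In this assay, (4-chlorophenoxy)methyl in place of 4-chlorophenoxy on the core of compound 3 gives a 2.5-fold higher number from compound 3 to compound 4 (0.39 log units; beyond the scatter). Both instances of the change point the same way, and their sizes cannot be told apart, so on these two cores the step carries over from one core to the other: the same change on two cores in this assay, a 1.8-fold higher number (0.26 log units; within the scatter) from compound 1 to compound 2 and a 2.5-fold higher number (0.39 log units; beyond the scatter) from compound 3 to compound 4, 1.4-fold (0.14 log units) apart, within the scatter of two such steps. This rests on one pair per core in a single cell assay, and only the newer step lies beyond the scatter on its own, so it shows neither that the change would carry to a third core nor why the number moves.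

Open, on these data alone, is how a longer chain, such as 2-(4-chlorophenoxy)ethyl at the same place, or a shorter chain would read on either core, and whether the step keeps its direction there. Also open, as far as these compounds go, is whether the same step would hold with an amine or a carboxylic acid in place of the chlorine on the end group.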